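From 2-chlorophenyl to 2,4-dimethylphenyl on the shared core

The source may report more compounds than this note shows. Statements on the series, on what has been measured and on what is new or still open speak of the compounds shown alone.

In a functional assay on MCF7 cells (Homo sapiens) for antiproliferative activity, read by MTT assay, with a stated time of 48 h (a higher number here means a weaker inhibitor, a lower number a stronger inhibitor), compound 1 `O=C(/C=C/c1ccc(O)c(O)c1)N1CCN(c2ccccc2Cl)CC1` gives 1.36 ug/mL. Compound 3 `O=C(/C=C/c1ccc(O)c(O)c1)N1CCN(c2cccc(C(F)(F)F)c2)CC1` gives 1.24 ug/mL, within the scatter of compound 1, while compound 2 `COc1ccccc1N1CCN(C(=O)/C=C/c2ccc(O)c(O)c2)CC1` gives 0.54 ug/mL. Compound 4 `Cc1ccc(N2CCN(C(=O)/C=C/c3ccc(O)c(O)c3)CC2)c(C)c1` carries 2,4-dimethylphenyl in place of 2-chlorophenyl on an amine nitrogen in a ring. Among the measured compounds shown here, the one measured step that bears on this is the modest 2.5-fold lower number from compound 1 to compound 2 (0.40 log units; beyond the scatter), where methoxy replaces the same chloro. For the measured compounds named here, no measured compound carries methyl, so that step is only a loose guide. A small shift towards a lower number is expected, with an estimated step of a 1.4-fold lower number from compound 1 to compound 4 (0.16 log units; within the scatter), probably not beyond the scatter. The estimate for compound 4 is 0.95 ug/mL, with an expected range of 0.42 ug/mL to 2.1 ug/mL.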

Compound 4, half-maximal inhibitory concentration: 0.78 ug/mL
Compound 4: the middle estimate sits 1.2-fold (0.09 log units) above what was measured; the range from low to high includes it.
By their numbers in this assay, from the lowest: compounds 2, 4, 3 and 1 (each within the scatter of the next, the first and the last beyond it).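

In this assay, 2,4-dimethylphenyl on the amine nitrogen in a ring gives a 1.7-fold lower number from compound 1 to compound 4 (0.24 log units; within the scatter) and a 1.4-fold higher number from compound 2 to compound 4 (0.16 log units; within the scatter). This position therefore accepts a group with neither chlorine nor oxygen, and compound 4 cannot be placed on either side of the gap shown by a 2.5-fold lower number from compound 1 to compound 2 (0.40 log units; beyond the scatter). No measurement here offers an explanation for these steps.

Going by these compounds, whether an amine or a carboxylic acid on the phenyl group would keep the numbers in this range remains open. On these data alone, the contribution of a single methyl group also remains open.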